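Ethoxy for phenyl: the step from compound 2 to compound 4

This account rests on a few compounds, and the source may have more. Where it says the series, first, only, none or still open, it means among the compounds named here.

Three members of the series have been measured in a functional assay on KB cells (Homo sapiens) for inhibition; a lower number here means a stronger inhibitor, a higher number a weaker inhibitor. Compound 1, `CNc1c(C#N)c2c(N)ncnc2n1COCCOC`, gives only a limit, > 100000 nM, in this assay. Compound 3, `N#Cc1c(Br)n(COCc2ccccc2)c2ncnc(N)c12`, likewise gives only a limit, > 100000 nM, in this assay. For the measured compounds named here, compound 2, `N#Cc1c(N)n(Cc2ccccc2)c2ncnc(N)c12`, is the one member with a number: in this assay compound 2 gives 34000 nM. Compound 2 therefore stands alone among the measured results, since the other two are the limit of > 100000 nM in this assay, at which 2 of the 3 values shown sit. Going by the values given here, no two measured compounds differ in a single place, so no measured step is available for comparison, and compound 1 and compound 3, each differing from compound 2 in more than one place, both returned limits rather than numbers.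

Compound 4, `CCOCn1c(N)c(C#N)c2c(N)ncnc21`, has not been measured. It differs from compound 2 by ethoxy in place of phenyl on a saturated chain carbon bound to an aromatic nitrogen. Among the compounds with values here, with no measured step to lean on, the expectation is a move toward weaker inhibition in this assay, beyond the usual scatter, and the expected step is a 2.4-fold higher number from compound 2 to compound 4 (0.37 log units; beyond the scatter). For compound 4 in this assay the estimate is 80000 nM, with a range from 25000 nM to 300000 nM, and a fair chance that only a limit is reported.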

Compound 4, half-maximal inhibitory concentration: 138000 nM
Compound 4: middle estimate off by 1.7-fold (0.24 log units), on the low side, and the stated range covers the measured number.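

In this assay, for the compounds shown here, ethoxy in place of phenyl gives a 4.1-fold higher number from compound 2 to compound 4 (0.61 log units; beyond the scatter), the first step that changes a single place, and it runs toward weaker inhibition. This place on the saturated chain carbon bound to an aromatic nitrogen is therefore sensitive to the change, although removing the phenyl ring does not leave compound 4 without a measurable number. That number falls in the region where the other non-numeric readings of the series are limits, which shows that this assay can still give a value there: the limit of > 100000 nM in this assay, at which 2 of the 4 values shown sit.

Going by these compounds alone, the single step cannot separate the loss of the six-membered aromatic ring from the smaller heavy-atom count or the added hydrogen-bond acceptor, as all three change together. From the compounds shown here alone, a propyl group, with no ring and no oxygen, and a cyclohexyl group, with a ring that is not aromatic, would help to pull these apart, and it remains open whether any group at this place can give a lower number than compound 2.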